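The source may report more compounds than this note shows. Statements on the series, on what has been measured and on what is new or still open speak of the compounds shown alone.

In a functional assay on SNB-19 cells (Homo sapiens) for cytotoxicity, read by sulforhodamine B assay, with a stated time of 48 h, tested at 0.01 uM (on this read-out higher numbers stand for a weaker effect at the one concentration tested and lower numbers for a stronger effect), three compounds have been measured. Compound 1 `COc1cc(C)cc(-c2c(-c3ccnc(-c4ccc(N(C)C)cc4)c3)cnn2CC#N)c1` gives 44%. Compound 2 `COc1cc(C)cc(-c2nn(CC#N)cc2-c2ccnc(-c3ccc(N(C)C)cc3)c2)c1` gives 97%, and compound 3 `COc1cc(C)cc(-c2nn(CC#N)cc2-c2ccc(-c3cccc(C(C)=O)c3)nc2)c1` gives 102%. Compound 2 thus holds the second highest of the three numbers: compound 3 is its nearest neighbour, a number higher yet within the usual scatter, while compound 1 is furthest from it, a number beyond the scatter and far lower.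

Compound 4 `Cc1cc(O)cc(-c2nn(CC#N)cc2-c2ccnc(-c3ccc(N(C)C)cc3)c2)c1` has not yet been tested. It differs from compound 2 in one place: hydrogen in place of methyl on an oxygen on an aromatic ring; in other words, methoxy becomes hydroxy, so the 3-methoxy-5-methylphenyl ring becomes a 3-hydroxy-5-methylphenyl ring. No pair of measured compounds shows this change, so the effect of the step is not known from the numbers shown. The step from compound 2 to compound 4 is expected to be small, a number 2 percentage points lower from compound 2 to compound 4 (within the scatter), and to stay within the scatter. Compound 4 is therefore estimated to give 95%, with a likely range from 75% to 110%.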

Compound 4, a percentage reported as activity, at one concentration (the size of the read-out at that concentration, not a potency): 95%
For compound 4 middle estimate and measured number coincide at the digits printed; measured number inside the range.
By their numbers in this assay, from the lowest: compound 1; then compounds 4, 2 and 3 (each within the scatter of the next).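

In this assay, putting hydrogen in place of the methyl on the oxygen gives a number 2 percentage points lower from compound 2 to compound 4 (within the scatter), the first step shown that changes only this one place, so the hydroxy and methoxy forms cannot be told apart here. On the core of compound 2, then, this methyl can be removed with no change beyond the scatter, though both compounds remain at the weak end of this read-out, where a step that improves the effect would be visible but none appears. Nothing measured here offers an explanation for this result.

Going by these compounds, whether the same swap would read alike on the core of compound 1, which shows a stronger effect, stays open. Also open, on these data alone, is how this position would respond to an amine or a carboxylic acid on the ring, or to a longer chain such as ethyl or propyl on the oxygen.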